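The source may report more compounds than this note shows. Statements on the series, on what has been measured and on what is new or still open speak of the compounds shown alone.

Values in a functional assay on MCF-10A cells (Homo sapiens) for antiproliferative activity, with a stated time of 48 h (on this read-out lower numbers stand for an effect already at smaller amounts and higher numbers for an effect only at larger amounts of compound), as measured so far
- compound 1 (`COc1ccc2nc(C)cc(NCc3cccc(-c4ccccc4)c3)c2c1`) 2800 nM
- compound 2 (`COc1ccc2nccc(NCc3ccc(F)cc3)c2c1`) 13300 nM

Compound 2 at 13300 nM holds the higher of the two numbers and compound 1 at 2800 nM the lower, a gap beyond the scatter. Compound 3 (`COc1ccc2nc(CO)cc(NCc3ccc(F)cc3)c2c1`) differs from compound 2 in one place: hydroxymethyl in place of hydrogen on an aromatic carbon, next to the ring nitrogen (hydroxymethyl in place of hydrogen on an aromatic carbon). For the measured compounds named here, no measured pair differs in one place only, so nothing measured shows the size of such a change in this assay and the expectation rests on the value of compound 2 (13300 nM) alone. The expected outcome is no step beyond the scatter (a 1.2-fold lower number from compound 2 to compound 3 (0.08 log units; within the scatter)). For compound 3 the estimated value is 11000 nM (expected range 4000 nM to 30000 nM).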

Compound 3, half-maximal effective concentration: 20800 nM
Compound 3: middle estimate off by 1.9-fold (0.28 log units), on the low side; measured number inside the range.
By their numbers in this assay, from the lowest: compound 1; then compounds 2 and 3 (each within the scatter of the next).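

In this assay, for the compounds shown here, hydroxymethyl in place of hydrogen on an aromatic carbon, next to the ring nitrogen, gives a 1.6-fold higher number from compound 2 to compound 3 (0.19 log units; within the scatter) as the only single-place step so far. This position therefore accepts a hydroxymethyl group with no step beyond the scatter on this read-out, which compounds 1 and 2 alone could not show. No supporting measurement is available to explain this result.

Going by these compounds, whether a carboxylic acid, an aminomethyl group or a longer chain at the same position would give a step beyond the scatter remains open. On these data alone, compound 1 differs from compound 2 and compound 3 in more than one place, so the contribution of its methyl group at this position also remains open.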